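A few compounds are considered here, and "the series" means these few. Any claim that something is new, unique, unknown or untested is made for them only; others in the source may bear on it.

Two compounds of this series have numbers in a functional assay on BT-549 cells (Homo sapiens) for inhibition, read by sulforhodamine B assay, with a stated time of 48 h, tested at 10 uM; on this read-out higher numbers stand for a weaker effect at the one concentration tested and lower numbers for a stronger effect. Compound 1 `COc1cc(Cl)cc(-c2nn(-c3cccc(NC(=O)c4ccc(Cl)c(Cl)c4)c3)cc2-c2ccncc2)c1` gives 85.2% in this assay. Compound 2 `COc1cc(Cl)cc(-c2nn(-c3cccc(NC(=O)Nc4ccc(Cl)c(C(F)(F)F)c4)c3)cc2-c2ccncc2)c1` gives 9.81% in this assay, and the step of a number 75.4 percentage points lower from compound 1 to compound 2 (beyond the scatter) is the only measured one; it changes two things at once, the amide to a urea and the aryl substituent. Compound 2 thus holds the lowest of the two numbers, with compound 1 the nearest and beyond the scatter above it.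

Compound 3 `COc1cc(Cl)cc(-c2nn(-c3cccc(NC(=O)Nc4ccc(Cl)c(Cl)c4)c3)cc2-c2ccncc2)c1` keeps the urea of compound 2 and differs from it only in chloro in place of trifluoromethyl on an aromatic carbon, so it carries the same 3,4-dichlorophenyl as compound 1 on a urea instead of an amide. Among the measured compounds shown here, no measured step isolates this change; the step from compound 1 to compound 2 bears on it only in part, since compound 3 undoes one of its two alterations. If the urea accounts for most of that step, a small rise in this assay is expected for compound 3, as a number 10.2 percentage points higher from compound 2 to compound 3 (beyond the scatter), within or just beyond the scatter. For compound 3 a value of 20% is estimated in this assay, within 5% to 55%.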

Compound 3, a percentage reported as activity, at one concentration (the size of the read-out at that concentration, not a potency): 29.4%
Beside the measured number, compound 3's estimate is 9.4 percentage points below it; the measured number falls inside the stated range.
By their numbers in this assay, from the lowest: compound 2; then compound 3; then compound 1.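

On this assay the amide and urea effects can now be read separately: with 3,4-dichlorophenyl held fixed, the urea in place of the amide gives a number 55.8 percentage points lower from compound 1 to compound 3 (beyond the scatter) and thus accounts for a large change on its own, which the earlier pair, altered in two places, could not show. The place ortho to a chloro group also responds on the urea, since chloro in place of trifluoromethyl gives a number 19.6 percentage points higher from compound 2 to compound 3 (beyond the scatter), a modest step that favours trifluoromethyl on this read-out and is smaller than the step from the linker change. Nothing available explains either step.

The compounds shown leave open whether trifluoromethyl at this place would give a comparable step on the amide, and whether a methoxy, a nitrile or a plain hydrogen there would follow either number. Also open, on these data alone, is how a thiourea or a carbamate in place of the urea would read, and whether the stronger and weaker effects seen at this one concentration would hold at other concentrations.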